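The compounds below may be only part of what the source reports. "The series", "measured", "known", "first", "only" and "open" are said of these compounds alone.

Compound 1 `CCCCCCCCCCn1c(=O)n(CCCCN2CCN(c3ccc(F)cc3)CC2)c2ccccc21` and compound 2 `CCCCCn1c(=O)n(CCCCN2CCN(c3ccc(F)cc3)CC2)c2ccc(C(C)=O)cc21` share a core but differ in two places at once. In an assay on membranes from brain for displacement of a labelled ligand from Sigma intracellular receptor 2 (Rattus norvegicus), read by radioligand binding, with a stated time of 120 min, in the presence of a further agent that is not named here (on this read-out higher numbers stand for weaker inhibition and lower numbers for stronger inhibition), compound 1 gives 4.55 nM. In this assay compound 2 gives 2.15 nM, the lower of the two numbers, and its gap to compound 1 lies beyond the usual scatter. Compound 3 `CCCCCCCCCCn1c(=O)n(CCCCN2CCN(c3ccc(F)cc3)CC2)c2ccc(C(C)=O)cc21` carries pentyl in place of hydrogen on a saturated chain carbon, five bonds along the chain from an aromatic nitrogen. Within the data shown here, no step between measured compounds that differ in one place is known. In this assay the expected step is a 1.2-fold higher number from compound 2 to compound 3 (0.08 log units; within the scatter), a small shift with no clear direction. Compound 3 is estimated at 2.6 nM, within 1 nM to 6.5 nM.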

Compound 3, inhibition constant: 32.5 nM
Estimate against measurement, compound 3: 13-fold (1.10 log units) below; the measured number lies above the stated range.
By their numbers in this assay, from the lowest: compound 2; then compound 1; then compound 3.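

In this assay the longer chain is costly on the acetyl-bearing core, with a 15-fold higher number from compound 2 to compound 3 (1.18 log units; beyond the scatter) for pentyl in place of hydrogen on a saturated chain carbon. Acetyl in place of hydrogen on an aromatic carbon also costs binding on the long-chain compound, with a 7.1-fold higher number from compound 1 to compound 3 (0.85 log units; beyond the scatter) for that change, so the earlier gap between compound 1 and compound 2 concealed two separate steps. No measurement here explains either step. As far as these compounds go, whether acetyl has the same effect on the shorter chain remains open. So does how an amine or a carboxylic acid would behave in its place.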